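Fluoro for trifluoromethyl on the benzamide of compound 2

The source may report more compounds than this note shows. Statements on the series, on what has been measured and on what is new or still open speak of the compounds shown alone.

Of the compounds shown here, two have been measured so far in a functional assay on Raji cells (Homo sapiens) for antiproliferative activity, read by CCK-8 assay, with a stated time of 72 h, tested at 40 uM; a lower number here means less inhibition, a higher number more inhibition at the concentration tested (going by the name of the read-out). Compound 1, `CCOC(=O)c1sc(-c2cccc(NC(=O)c3ccc(F)cc3)c2)nc1Nc1ccc(N2CCN(C)CC2)cc1`, gives 16.8%. Compound 2, `CN1CCN(c2ccc(Nc3nc(-c4cccc(NC(=O)c5ccc(C(F)(F)F)cc5)c4)sc3C(N)=O)cc2)CC1`, gives 91.9% and so stands highest of the two, with compound 1 a distance below it that lies beyond the usual scatter. Compound 1 and compound 2 differ in two places at once, so their two values alone do not tell which of the two changes carries the gap.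

Compound 3, `CN1CCN(c2ccc(Nc3nc(-c4cccc(NC(=O)c5ccc(F)cc5)c4)sc3C(N)=O)cc2)CC1`, has not yet been measured. It differs from compound 2 in one place: fluoro in place of trifluoromethyl on an aromatic carbon. The change sits on an aromatic carbon of a six-membered aromatic ring of carbon only, para to a large group, and leaves the rest of compound 2 unchanged.

Among the compounds with values here, no step between measured compounds isolates this change. Since compound 2 and compound 3 share everything else, compound 3 is expected to remain nearer to compound 2 than to compound 1, with a step of a number 19.9 percentage points lower from compound 2 to compound 3 (beyond the scatter) in this assay that is expected to be modest and downward, though it may well fall within the scatter. For compound 3 the estimate is 72%, within a range from 35% to 95%.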

Compound 3, a percentage reported as inhibition, at one concentration (the size of the read-out at that concentration, not a potency): 95.3%
Estimate against measurement, compound 3: 23.3 percentage points below; measured number above the stated range.
By their numbers in this assay, from the lowest: compound 1; then compounds 2 and 3 (each within the scatter of the next).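

In this assay, fluoro in place of trifluoromethyl on an aromatic carbon, para to a large group, gives a number 3.4 percentage points higher from compound 2 to compound 3 (within the scatter), so this position accepts either group without a change that can be told from the scatter, even though three fewer heavy atoms are present with fluoro. Compound 3 also forms a single-change pair with compound 1, and amino in place of ethoxy on a carbonyl carbon gives a number 78.5 percentage points higher from compound 1 to compound 3 (beyond the scatter), a large step that ties the low reading of compound 1 to the ethoxy group, while the choice between the two aromatic substituents makes no visible difference. Nothing measured here offers an explanation for either step.

As far as these compounds go, whether an unsubstituted phenyl ring, or a methoxy or nitrile group at the same aromatic carbon, would keep the inhibition remains open, as does whether a carboxylic acid or a methylamino group on the carbonyl carbon would read like amino or like ethoxy. From the compounds shown here alone, with a read-out taken at a single concentration, it also remains open whether compound 2 and compound 3 would separate in potency.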